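Removing the methoxy from a benzyl thioimidate

The source may hold more compounds than are shown below. What is called first, only, known or untested is meant among the compounds shown, and "the series" means these compounds.

Measured so far in an ADME assay for pharmacokinetics, in phosphate buffer, with a stated time of 30 min, at pH 7.4, tested at 1 mM, at a dose of 1 mM, in the absence of a further agent; on this read-out lower numbers stand for lower exposure and higher numbers for higher exposure at the dose given:
compound 1 `S=C(NCc1ccccc1)c1cccs1`, < 300 nM
compound 2 `COc1ccc(C(=N)SCc2ccccc2)cc1`, 1180 nM
compound 3 `N=C(SCc1ccccc1)c1cccs1`, 1900 nM

In this assay compound 2 gives 1180 nM. In this assay compound 3 gives 1900 nM. These two numbers sit within the usual scatter of each other, so compound 2 and compound 3 cannot be told apart on this read-out. For compound 1 the result in this assay is a limit of the assay and not a number (the limit of < 300 nM in this assay, at which 1 of the 3 values shown sits).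

Compound 4 `N=C(SCc1ccccc1)c1ccccc1` differs from compound 2 in one place: hydrogen in place of methoxy on an aromatic carbon. Going by the values given here, no step between measured compounds is available to set the size of this change. What the data show is that two quite different structures, compound 2 and compound 3, land within the scatter of each other in this assay, and on that basis the step from compound 2 to compound 4 is expected to be small, with no clear direction beyond the scatter, as a 1.1-fold higher number from compound 2 to compound 4 (0.04 log units; within the scatter). Compound 4 is therefore expected to give 1300 nM, between 500 nM and 3200 nM, in this assay.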

Compound 4, maximal plasma concentration in the ADME assay: 2300 nM
Beside the measured number, compound 4's estimate is 1.8-fold (0.25 log units) below it, and the stated range covers the measured number.
By their numbers in the ADME assay, from the lowest: compounds 2, 3 and 4 (each within the scatter of the next). At a limit, below all of these: compound 1.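

In the ADME assay the change from methoxy to hydrogen is a 1.9-fold higher number from compound 2 to compound 4 (0.29 log units; within the scatter), so this replacement, on an aromatic carbon para to a large group, does not separate the two compounds on that read-out. In a physicochemical assay for pharmacokinetics, in phosphate buffer, with a stated time of 30 min, at pH 7.4, tested at 1 mM, in the absence of a further agent (on this read-out higher numbers stand for a longer-lived compound and lower numbers for a shorter-lived compound), compound 2 has 0.289 h and compound 4 has 0.0602 h. Going by these compounds alone, in the physicochemical assay the same change is a 4.8-fold lower number from compound 2 to compound 4 (0.68 log units; beyond the scatter), which shows that this one place can matter on one read-out while staying within the scatter on the other, something the earlier compounds, with no step between them, could not show.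

The compounds shown leave open whether a different group at this place, such as an amine, a chlorine or a carboxylic acid, would keep the longer half-life of compound 2. They also leave open what lies behind the shorter half-life of compound 4.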